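This account rests on a few compounds, and the source may have more. Where it says the series, first, only, none or still open, it means among the compounds named here.

Measured so far:
compound 1 `O=C1CNC(=O)N1C[C@H]1CN(c2ccc(-n3cc(-c4ccccn4)cn3)c(F)c2)C(=O)O1` — 1630000 nM
compound 2 `O=C1CSC(=O)N1C[C@H]1CN(c2ccc(-n3cc(-c4ccccn4)cn3)c(F)c2)C(=O)O1` — 26900 nM
compound 3 `O=C(OC[C@H]1CN(c2ccc(-n3cc(-c4ccccn4)cn3)c(F)c2)C(=O)O1)c1ccccc1` — <= 65400 nM (a limit)

In a physicochemical assay for solubility, read by HPLC, with a stated time of 24 h (a higher number here means a more soluble compound, a lower number a less soluble compound), compound 1 gives 1630000 nM and compound 2 gives 26900 nM, the step between them being a 61-fold lower number from compound 1 to compound 2 (1.78 log units; beyond the scatter). For compound 3 this assay reports only a limit, <= 65400 nM; it is the limit (the limit of <= 65400 nM in this assay, at which 1 of the 3 values shown sits). Compound 3 therefore stands at the bottom of what is shown: the step of an at least 24-fold lower number from compound 1 to compound 3 (1.39 log units; beyond the scatter) is readable, whereas a step that the limit leaves unreadable from compound 2 to compound 3.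

Compound 4 `O=C1O[C@@H](CSc2cccs2)CN1c1ccc(-n2cc(-c3ccccn3)cn2)c(F)c1` differs from compound 3 in that ((thiophen-2-yl)sulfanyl in place of benzoyloxy on a saturated chain carbon bound to a saturated ring carbon). Going by the values given here, none of the measured steps touches this change: the two readable steps both start from the 2,5-dioxoimidazolidin-1-yl of compound 1 and were large, while the step from compound 2 to compound 3 cannot be read. Compound 3 already sits at the limit, so the step that the limit leaves unreadable from compound 3 to compound 4 is expected to be small, and a further limit reading is quite possible. Compound 4 is estimated in this assay at 20000 nM, with a range from 3000 nM to 65400 nM.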

Compound 4, solubility: 8500 nM
Compound 4: middle estimate off by 2.4-fold (0.37 log units), on the high side; low and high end bracket the measured number.
By their numbers in this assay, from the lowest: compound 4; then compound 2; then compound 1.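

Going by these compounds alone, with (thiophen-2-yl)sulfanyl on the saturated chain carbon bound to a saturated ring carbon, this position gives the first exact reading in this assay for a group without a dioxo ring, and the number falls further, with a 3.2-fold lower number from compound 2 to compound 4 (0.50 log units; beyond the scatter) and a 190-fold lower number from compound 1 to compound 4 (2.28 log units; beyond the scatter). Among compound 1, compound 2 and compound 4, the numbers therefore separate beyond the scatter, with compound 4 lowest, so the change of group alone spans a wide range at this place. The step between compound 3 and compound 4 cannot be read, as the value of compound 3 is a limit: the limit of <= 65400 nM in this assay, at which 1 of the 4 values shown sits.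

The compounds shown do not separate the contribution of the sulfur link from that of the thiophene ring, which a phenylsulfanyl group could address. As far as these compounds go, whether an amine or a carboxylic acid at this place would restore numbers near that of compound 1 remains open.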